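Adding a Hydroxy Group to Compound 2

The compounds below may be only part of what the source reports. "The series", "measured", "known", "first", "only" and "open" are said of these compounds alone.

Of the compounds shown here, two have been measured in a functional assay on the whole organism (Hindlimb, strain albino) with Mus musculus as the target, in the maximal electroshock model, with a stated time of 0.5 h; a higher number here means that more compound is needed for the effect, a lower number that less compound is needed. Compound 1 `COc1ccc(/C=C/C(=O)Nc2nc3ccc(Cl)cc3s2)cc1O` gives 320 umol/kg in this assay. Compound 2 `COc1ccc(C2CC(Nc3nc4ccc(C)cc4s3)=NN2C(C)=O)cc1` gives 37.3 umol/kg, the lower of the two numbers; its gap to compound 1 is beyond the usual scatter. Compound 3 `COc1ccc(C2CC(Nc3nc4ccc(C)cc4s3)=NN2C(C)=O)cc1O` differs from compound 2 by hydroxy in place of hydrogen on an aromatic carbon. Among the measured compounds shown here, no measured pair shows what this change does on the shared core of compound 2; compound 1 carries the same 3-hydroxy-4-methoxyphenyl group on another core and offers no direct step. The step of a 1.5-fold higher number from compound 2 to compound 3 (0.17 log units; within the scatter) is expected to stay small, within the scatter or slightly toward more compound. Compound 3 is estimated at 55 umol/kg, between 20 umol/kg and 150 umol/kg.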

Compound 3, dose for half-maximal effect: 73.9 umol/kg
Compound 3: middle estimate off by 1.3-fold (0.13 log units), on the low side, and the stated range covers the measured number.
By their numbers in this assay, from the lowest: compounds 2 and 3 (each within the scatter of the next); then compound 1.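

Among the compounds shown here, on the shared core of compound 2, the hydroxy group placed ortho to a methoxy group gives in this assay a 2.0-fold higher number from compound 2 to compound 3 (0.30 log units; within the scatter) and this is the first direct reading of the change. The position thus accepts the step from 4-methoxyphenyl to 3-hydroxy-4-methoxyphenyl with no shift beyond the scatter. Nothing at hand explains this result.

On these data alone, it remains open whether an amine or a carboxylic acid at this position would also stay within the scatter. As far as these compounds go, the effect of removing the hydroxy group from the core of compound 1 also remains open.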